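A few compounds are considered here, and "the series" means these few. Any claim that something is new, unique, unknown or untested is made for them only; others in the source may bear on it.

Compound 1 `Nc1ccccc1NC(=O)c1ccc(CSC(=S)N2CCc3cc([N+](=O)[O-])ccc32)cc1`: 26.8%
Compound 2 `CCN(Cc1ccncc1)C(=S)SCc1ccc(C(=O)Nc2ccccc2N)cc1`: 71.6%

In a functional assay on MGC-803 cells (Homo sapiens) for antiproliferative activity, read by CCK-8 assay, with a stated time of 72 h, tested at 2 uM (on this read-out higher numbers stand for a stronger effect at the one concentration tested and lower numbers for a weaker effect), compound 2 stands highest of the two numbers, and compound 1 sits well beneath it, a gap beyond the usual scatter. Compound 3 `CN(Cc1cccnc1)C(=S)SCc1ccc(C(=O)Nc2ccccc2N)cc1` is the unmeasured member; it differs from compound 2 in one place: methyl((pyridin-3-yl)methyl)amino in place of ethyl((pyridin-4-yl)methyl)amino on a thiocarbonyl carbon. Within the data shown here, no measured pair shows what such a change does, so only a small shift is expected, downward if anything and not beyond the scatter a number 6.6 percentage points lower from compound 2 to compound 3 (within the scatter). Compound 3 is therefore expected to give about 65% in this assay, somewhere between 45% and 82%.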

Compound 3, a percentage reported as inhibition, at one concentration (the size of the read-out at that concentration, not a potency): 45.9%
Beside the measured number, compound 3's estimate is 19.1 percentage points above it; low and high end bracket the measured number.
By their numbers in this assay, from the lowest: compound 1; then compound 3; then compound 2.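

In this assay, placing methyl((pyridin-3-yl)methyl)amino in place of ethyl((pyridin-4-yl)methyl)amino on a thiocarbonyl carbon gives a number 25.7 percentage points lower from compound 2 to compound 3 (beyond the scatter) at this position. Among these compounds, this is the first sign that the read-out responds to a change within this amino group, even though both groups carry a six-membered aromatic ring with one hetero atom. No available evidence accounts for the size of this step.

Going by these compounds, the step changes the alkyl chain and the pyridine attachment together, so the share of each remains open. A group such as ethyl((pyridin-3-yl)methyl)amino or methyl((pyridin-4-yl)methyl)amino would separate the two changes.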